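A few compounds are considered here, and "the series" means these few. Any claim that something is new, unique, unknown or untested is made for them only; others in the source may bear on it.

Compounds measured so far:
compound 1, `Nc1ccccc1NC(=O)c1ccc(CSC(=S)N2CCN(Cc3ccccn3)CC2)cc1` — 14.2%
compound 2, `CCN(Cc1ccncc1)C(=S)SCc1ccc(C(=O)Nc2ccccc2N)cc1` — 63.5%

The study examines a pair of benzamide-linked dithiocarbamates in a functional assay on HeLa cells (Homo sapiens) for antiproliferative activity, read by CCK-8 assay, with a stated time of 72 h, tested at 2 uM; on this read-out lower numbers stand for a weaker effect and higher numbers for a stronger effect at the one concentration tested. Compound 1, `Nc1ccccc1NC(=O)c1ccc(CSC(=S)N2CCN(Cc3ccccn3)CC2)cc1`, gives 14.2% in this assay, the lower of the two numbers in hand. For the measured compounds named here, compound 2, `CCN(Cc1ccncc1)C(=S)SCc1ccc(C(=O)Nc2ccccc2N)cc1`, gives 63.5% in this assay, a number well above compound 1 and beyond the usual scatter; as no single-point step joins the two structures, the account records only what their two values show.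

Compound 3, `Nc1ccccc1NC(=O)c1ccc(CSC(=S)N2CCN(C3CCCCC3)CC2)cc1`, remains to be measured in this assay. It departs from compound 1 in one place: cyclohexyl in place of (pyridin-2-yl)methyl on an amine nitrogen in a ring. Going by the values given here, no comparable step between measured compounds exists to anchor an expectation, so the size and direction of the change in this assay are uncertain. The account expects a modest rise, a number 10.8 percentage points higher from compound 1 to compound 3 (beyond the scatter), but with a wide range that also admits no change beyond the scatter. For compound 3 the estimate in this assay is 25%, between 5% and 55%.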

Compound 3, a percentage reported as inhibition, at one concentration (the size of the read-out at that concentration, not a potency): 30.6%
Beside the measured number, compound 3's estimate is 5.6 percentage points below it; low and high end bracket the measured number.
By their numbers in this assay, from the lowest: compound 1; then compound 3; then compound 2.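

In this assay, for the compounds shown here, the swap of cyclohexyl for (pyridin-2-yl)methyl on an amine nitrogen in a ring gives a number 16.4 percentage points higher from compound 1 to compound 3 (beyond the scatter) and is the first comparison here confined to one place, which the two earlier compounds, differing in more than one place, could not offer. It shows that the read-out responds to the group carried on this nitrogen, and that a non-aromatic ring of carbon only can stand there in place of an aromatic ring with a hetero atom and still give the higher number of the pair. The change alters several things at once, including the ring type, the hydrogen-bond acceptor and the link to the ring, and nothing available bears on which of these accounts for the step.

A benzyl group on the same nitrogen would help separate the part played by the pyridine nitrogen from that of the aromatic ring, while a phenyl group would test the methylene link. Also open, as far as these compounds go, is how a methyl group, a longer chain or a hydroxyl group on the cyclohexyl would read at this position.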